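A Chloro-for-Fluoro Swap Starting From a Limit

A few compounds are considered here, and "the series" means these few. Any claim that something is new, unique, unknown or untested is made for them only; others in the source may bear on it.

In a functional assay on SW-620 cells (Homo sapiens) for inhibition, read by MTT assay, with a stated time of 72 h (a higher number here means a weaker inhibitor, a lower number a stronger inhibitor), compound 1 `COc1cc(NC(C)CCCNC(=O)Nc2cccc(Cl)c2)c2ncccc2c1` gives 26000 nM and compound 2 `COc1cc(NC(C)CCCNC(=O)Nc2ccc(Br)cc2)c2ncccc2c1` gives 23000 nM. Compound 3 `COc1cc(NC(C)CCCNC(=O)NNC(=O)Nc2ccc(F)cc2)c2ncccc2c1` gives > 100000 nM, which is a limit of the assay and not a number. Its true value is therefore unknown, and it stands behind both of the others, with an at least 3.8-fold higher number from compound 1 to compound 3 (0.58 log units; beyond the scatter) and an at least 4.3-fold higher number from compound 2 to compound 3 (0.63 log units; beyond the scatter). Those two steps replace the whole aryl end of the molecule, so they say little about a single halogen.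

Compound 4 `COc1cc(NC(C)CCCNC(=O)NNC(=O)Nc2ccc(Cl)cc2)c2ncccc2c1` differs from compound 3 by one small exchange: chloro in place of fluoro on an aromatic carbon, with chloro in place of fluoro on an aromatic carbon. The nearest guide is another halogen-bearing change, 4-bromophenyl in place of 3-chlorophenyl, which gave a 1.1-fold lower number from compound 1 to compound 2 (0.05 log units; within the scatter). That step stays within the scatter, so no clear shift is expected in this assay. The expected step is a number no higher from compound 3 to compound 4 (the limit leaves the size open). For compound 4 the estimated value is 100000 nM, with an expected range of 40000 nM to 200000 nM.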

Compound 4, half-maximal inhibitory concentration: 48000 nM
Beside the measured number, compound 4's estimate is 2.1-fold (0.32 log units) above it, and the stated range covers the measured number.
By their numbers in this assay, from the lowest: compounds 2, 1 and 4 (each within the scatter of the next, the first and the last beyond it). At a limit, above all of these: compound 3.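

In this assay, a single halogen exchange on the aromatic carbon para to a large group is enough to bring this series from a limit to a measured number, giving an at least 2.0-fold lower number from compound 3 to compound 4 (0.31 log units; beyond the scatter) and showing that this position is not silent. Compound 3 stands at a limit and not at a number, so that step has a lower bound but no known size: the limit of > 100000 nM in this assay, at which 1 of the 4 values shown sits. Set against the earlier compounds, the chloro compound gives a 2.1-fold higher number from compound 2 to compound 4 (0.32 log units; beyond the scatter) but also a 1.8-fold higher number from compound 1 to compound 4 (0.27 log units; within the scatter) and so stands clearly apart only from compound 2.

One pair of halogens cannot show a trend at this position. On these data alone, how a bromo, methyl or trifluoromethyl group would read at the same place remains open, as does whether the exchange would hold with a longer chain.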